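Replacing trifluoromethoxy with chloro on the aromatic ring

A few compounds are considered here, and "the series" means these few. Any claim that something is new, unique, unknown or untested is made for them only; others in the source may bear on it.

In an ADME assay on Raji cells (Homo sapiens) for cytotoxicity, with a stated time of 72 h (on this read-out lower numbers stand for an effect already at smaller amounts and higher numbers for an effect only at larger amounts of compound), compound 1 `CCc1ccc(NC(=O)Nc2cc(C)nc3ccccc23)cc1` gives only a limit, > 25000 nM. For the measured compounds named here, compound 2 `Cc1cc(NC(=O)Nc2ccc(OC(F)(F)F)cc2)c2ccccc2n1` stands at 10000 nM, the only exact number so far. Going by the values given here, the sole measured guide is an at least 2.5-fold lower number from compound 1 to compound 2 (0.39 log units; beyond the scatter), where trifluoromethoxy replaced ethyl on an aromatic carbon. Compound 3 `Cc1cc(NC(=O)Nc2ccc(Cl)cc2)c2ccccc2n1` has chloro in place of trifluoromethoxy on that aromatic carbon, para to a large group: chloro in place of trifluoromethoxy on an aromatic carbon. With one bounded step to lean on, only a small shift toward a higher number is expected, an estimated 1.4-fold higher number from compound 2 to compound 3 (0.15 log units; within the scatter). Compound 3 is expected at about 14000 nM, with an estimated range of 6000 nM to 25000 nM.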

Compound 3, half-maximal effective concentration: > 25000 nM
Compound 3: a limit, no number (the forecaster's own chance of this, stated with the estimate: 25%); at least 1.7-fold (0.25 log units) between middle value and limit.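

In this assay, chloro does not keep the effect seen with trifluoromethoxy on this aromatic carbon: the change gives an at least 2.5-fold higher number from compound 2 to compound 3 (0.39 log units; beyond the scatter). The step between compound 1 and compound 3 cannot be read, since both values are limits and not numbers. Of the three groups at this place, only trifluoromethoxy gives an exact number: the limit of > 25000 nM in this assay, at which 2 of the 3 values shown sit.

On these data alone, how far compound 1 and compound 3 lie beyond their limits remains open. So does how an amine or a carboxylic acid on this aromatic carbon would read.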